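The source may hold more compounds than are shown below. What is called first, only, known or untested is meant among the compounds shown, and "the series" means these compounds.

Measured so far in a functional assay on the whole organism with Rattus norvegicus as the target, at a dose of 1 mg/kg by the oral route; a lower number here means a weaker effect, a higher number a stronger effect of the compound at the dose given:
compound 1 `COc1cc(C(=O)Nc2nn[nH]n2)nc(-c2ccc(C)cc2)c1` gives 42%
compound 2 `CCOc1cc(C(=O)Nc2nn[nH]n2)nc(-c2ccc(C)cc2)c1` gives 65%

Compound 2 stands highest of the two numbers; the nearest is compound 1, and the step of a number 23 percentage points higher from compound 1 to compound 2 (beyond the scatter) lies beyond the scatter. Compound 3 `CCOc1cc(C(=O)Nc2nn[nH]n2)nc(-c2ccc(N(CC)CC)cc2)c1` differs from compound 2 in one place: diethylamino in place of methyl on an aromatic carbon. Within the data shown here, no measured step touches this place. Among the measured compounds shown here, the only step known, a number 23 percentage points higher from compound 1 to compound 2 (beyond the scatter), concerns the saturated chain carbon bound to an oxygen on the aromatic ring, not the aromatic carbon where the diethylamino enters, so it carries no information on a change there. For the measured compounds named here, with no step to lean on, the expectation for compound 3 in this assay is no step beyond the scatter in either direction, held with wide uncertainty. Compound 3 is therefore estimated at 60%, in the range 30% to 85%. The step this estimate means, a number 5 percentage points lower from compound 2 to compound 3 (within the scatter), is expected to fall within the scatter.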

Compound 3, a percentage reported as inhibition, in the whole organism at one dose (the size of the read-out at that dose, not a potency): 66%
Beside the measured number, compound 3's estimate is 6 percentage points below it; measured number inside the range.
By their numbers in this assay, from the lowest: compound 1; then compounds 2 and 3 (each within the scatter of the next).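

In this assay the aromatic carbon, para to a large group, takes diethylamino in place of methyl with a number 1 percentage points higher from compound 2 to compound 3 (within the scatter) and no shift beyond the scatter, so the read-out at this dose holds with the larger group carrying a nitrogen. Within these compounds, the only step beyond the scatter remains a number 23 percentage points higher from compound 1 to compound 2 (beyond the scatter) at the saturated chain carbon bound to the oxygen, and the new step adds none at the aromatic carbon. No measurement at hand bears on why the read-out holds across this change.

Going by these compounds, whether a smaller amine such as dimethylamino or a carboxylic acid at the same aromatic carbon would also hold the read-out stays open. So does whether a longer chain on the oxygen, such as propoxy, would extend the earlier step.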